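The source may report more compounds than this note shows. Statements on the series, on what has been measured and on what is new or still open speak of the compounds shown alone.

Measured so far in a functional assay on B16-F10 cells (Mus musculus) for antiproliferative activity, read by MTT assay, with a stated time of 48 h; a lower number here means a stronger inhibitor, a higher number a weaker inhibitor:
- compound 1 `COc1ccc(/C=C/c2cc(OC)cc(OC)c2/C=C/C(=O)c2ccc(Cl)c(Cl)c2)cc1`: 7.5 ug/mL
- compound 2 `COc1ccc(/C=C/c2cc(OC)cc(OC)c2/C=C/C(=O)c2ccc(C)cc2)cc1`: 5.3 ug/mL
- compound 3 `CCCCCCOc1ccc(C(=O)/C=C/c2c(/C=C/c3ccc(OC)cc3)cc(OC)cc2OC)cc1`: 10.4 ug/mL

All three numbers lie within the usual scatter of one another, so compound 3 cannot be separated from compound 1 or compound 2 in this assay.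

Compound 4 `CCOc1ccc(C(=O)/C=C/c2c(/C=C/c3ccc(OC)cc3)cc(OC)cc2OC)cc1` differs from compound 3 by one change: hydrogen in place of butyl on a saturated chain carbon, two bonds along the chain from an oxygen on an aromatic ring. Put more simply, hexyloxy becomes ethoxy, a shorter chain.

For the measured compounds named here, two measured steps bear on this. The closer guide is a 2.0-fold higher number from compound 2 to compound 3 (0.29 log units; within the scatter), which puts hexyloxy in place of methyl. The other is a 1.4-fold lower number from compound 1 to compound 2 (0.15 log units; within the scatter), which puts 4-methylphenyl in place of 3,4-dichlorophenyl. Both are small, so no step beyond the scatter is expected here. Ethoxy is a shorter chain than hexyloxy, so a slight drift toward the number of compound 2 seems the likelier direction.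

The estimate therefore means a 1.4-fold lower number from compound 3 to compound 4 (0.14 log units; within the scatter), an expected step inside the scatter. For compound 4 the estimated value is 7.5 ug/mL, with an expected range from 4 ug/mL to 13 ug/mL.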

Compound 4, half-maximal inhibitory concentration: 6.4 ug/mL
The estimate for compound 4 lay 1.2-fold (0.07 log units) above the measured number, within the range that was stated.
By their numbers in this assay, from the lowest: compounds 2, 4, 1 and 3 (each within the scatter of the next).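

In this assay, going from hexyloxy to ethoxy gives a 1.6-fold lower number from compound 3 to compound 4 (0.21 log units; within the scatter), so removing the butyl part of this chain does not separate the two compounds. Ethoxy in place of methyl gives a 1.2-fold higher number from compound 2 to compound 4 (0.08 log units; within the scatter) and 4-ethoxyphenyl in place of 3,4-dichlorophenyl gives a 1.2-fold lower number from compound 1 to compound 4 (0.07 log units; within the scatter), so ethoxy adds a third comparison in which the compound cannot be told apart from its neighbour. No measurement offered here explains this flat picture.

From the compounds shown here alone, whether any change at this place can produce a step beyond the scatter remains open, for example a much longer chain such as dodecyloxy, or an amine or a carboxylic acid at the end of the chain. A bare hydroxyl on the ring in place of the ethoxy group also remains an open case.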